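The source may report more compounds than this note shows. Statements on the series, on what has been measured and on what is new or still open speak of the compounds shown alone.

Measured so far in an ADME assay on microsomes from liver (Rattus norvegicus) for metabolic stability, read by HPLC, using NADPH, with stated times of 5 min and 60 min, tested at 10 uM; on this read-out lower numbers stand for slow clearance and higher numbers for fast clearance:
- compound 1 `CCS(=O)(=O)Nc1ccc(Oc2ccc(C#N)cc2)c(-c2cn(C)c(=O)c3[nH]ccc23)c1`: 81.7 mL/min/kg
- compound 2 `Cn1cc(-c2cc(NS(C)(=O)=O)ccc2Oc2ccc(F)cc2F)c2cc[nH]c2c1=O`: < 65 mL/min/kg

Among the compounds with values here, compound 1 is the only compound with a numbered result in this assay, and in this assay compound 1 gives 81.7 mL/min/kg. Compound 2 reaches only a limit of the assay rather than a number, and in this assay compound 2 gives < 65 mL/min/kg; one of the two results sits at the limit of < 65 mL/min/kg in this assay, at which 1 of the 2 values shown sits. Within the data shown here, with one number and one limit, no step between measured compounds can be set out, so nothing tells how any single change shifts clearance here.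

Compound 3 `CCS(=O)(=O)Nc1ccc(OCC(C)(C)C)c(-c2cn(C)c(=O)c3[nH]ccc23)c1` differs from compound 1 in one place: neopentyl in place of 4-cyanophenyl on an oxygen on an aromatic ring. The shared core and the ethylsulfonamide are unchanged. Among the measured compounds shown here, since no measured step exists for this kind of change, the expectation for compound 3 rests on compound 1 alone, and it is expected that the step of a 1.1-fold lower number from compound 1 to compound 3 (0.04 log units; within the scatter) lies within the scatter of the assay, in no firm direction. Compound 3 is therefore estimated at 75 mL/min/kg, in the range 45 mL/min/kg to 125 mL/min/kg.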

Compound 3, clearance: 433 mL/min/kg
For compound 3 the middle estimate is 5.8-fold (0.76 log units) below the measured one; the measured number lies above the stated range.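

In this assay, neopentyl in place of 4-cyanophenyl on an oxygen on an aromatic ring gives a 5.3-fold higher number from compound 1 to compound 3 (0.72 log units; beyond the scatter), the only single change that can be read among the compounds shown. With the shared core and the ethylsulfonamide unchanged, this shows that clearance responds to the group at this position, as the step lies beyond the scatter and points towards faster clearance. Nothing measured here accounts for the size or direction of this step.

The pair leaves open whether the higher number goes with the loss of the nitrile, the loss of the aromatic ring, or the arrival of neopentyl itself, since all three come together in this one change. A plain phenyl on the same oxygen would separate the nitrile from the ring, while an n-butyl or a cyclohexylmethyl group would show whether other carbon groups without an aromatic ring follow neopentyl or stay closer to 4-cyanophenyl.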